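The compounds below may be only part of what the source reports. "The series", "measured", "known", "first", "only" and "open" are said of these compounds alone.

Among the compounds with values here, compound 1 `CCC(C)OC(=O)/C=C(C)/C=C/CC(C)CCCC(C)C` is the most lipophilic of the three compounds measured so far: in a physicochemical assay for lipophilicity (a higher number here means a more lipophilic compound, a lower number a more polar compound), compound 1 gives 7.69. Its nearest neighbour is compound 3 `CC(/C=C/CC(C)CCCC(C)(C)C)=C\C(=O)OC(C)C`, which in this assay gives 7.56, a number within the scatter of the value of compound 1. The furthest is compound 2 `CCC(C)OC(=O)/C=C(C)/C=C/CC(C)CCCC(C)(C)OC`, which in this assay gives 6.49; the step from compound 1 to compound 2 is a number 1.20 log units lower from compound 1 to compound 2 (beyond the scatter).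

Compound 4 `C=CCSC(=O)/C=C(C)/C=C/CC(C)CCCC(C)C` differs from compound 1 in one place: allylsulfanyl in place of sec-butoxy on a carbonyl carbon. Within the data shown here, none of the measured steps touches the carbonyl carbon or its substituent; the only step available, from compound 1 to compound 2, concerns a methoxy on a saturated chain carbon and does not bear on this change. The change in compound 4 swaps a group of five heavy atoms for one of four heavy atoms with a sulfur and a double bond, so no step beyond the scatter is expected in this assay, and the value for compound 4 is estimated at 7.55, between 7.05 and 8.05, a step of a number 0.14 log units lower from compound 1 to compound 4 (within the scatter).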

Compound 4, partition coefficient: 7.97
For compound 4 the middle estimate is 0.42 log units below the measured one; the range from low to high includes it.
By their numbers in this assay, from the lowest: compound 2; then compounds 3, 1 and 4 (each within the scatter of the next, the first and the last beyond it).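

Within the data shown here, with allylsulfanyl in place of sec-butoxy on a carbonyl carbon, the study records a number 0.28 log units higher from compound 1 to compound 4 (within the scatter) in this assay and so gives its first reading at this position, which the earlier steps did not touch. This change brings in sulfur and a double bond together, yet its step stands within the scatter, unlike a number 1.20 log units lower from compound 1 to compound 2 (beyond the scatter) at a saturated chain carbon of the same core. Nothing in the data at hand offers a reason for this result.

Since the sulfur and the double bond enter together, this one pair cannot separate them, and allyloxy or propylsulfanyl on the same carbonyl carbon would be needed to do so. Going by these compounds, how an amine or a hydroxyl group at this position would read in this assay also remains open.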